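Swapping a Dimethoxyphenyl Group for a Dichlorophenyl Group

The source may hold more compounds than are shown below. What is called first, only, known or untested is meant among the compounds shown, and "the series" means these compounds.

Compound 1 `COc1cc(/C=C2\CN(C)C/C(=C\c3ccccc3F)C2=O)cc(OC)c1` gives 5450 nM
Compound 2 `CN1C/C(=C\c2ccc(C(C)(C)C)cc2)C(=O)/C(=C/c2ccccc2F)C1` gives 15500 nM
Compound 3 `COc1cc(/C=C2\CN(C)C/C(=C\c3cc(OC)c(OC)c(OC)c3)C2=O)cc(OC)c1` gives 2300 nM

These numbers come from a functional assay on HeLa cells (Homo sapiens) for cytotoxicity, read by MTT assay, with a stated time of 24 h (a lower number here means a stronger inhibitor, a higher number a weaker inhibitor), and the three compounds share one core. Compound 3 has the lowest number of the three, and its gaps to compound 1 and compound 2 lie beyond the usual scatter, so it is the strongest inhibitor of this small set. The unmeasured compound 4 `COc1cc(/C=C2\CN(C)C/C(=C\c3ccc(Cl)cc3Cl)C2=O)cc(OC)c1OC` differs from compound 3 by one exchange: 2,4-dichlorophenyl in place of 3,5-dimethoxyphenyl on a double-bonded chain carbon bound to a double-bonded ring carbon.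

Among the compounds with values here, no two measured compounds differ in just one place, so no direct step guides this change. Compound 1 and compound 2 each carry a halogen, as compound 4 does, and both have higher numbers than compound 3, which has none. Across three compounds, this is only a loose hint. In this assay a small move toward a higher number is expected, possibly no larger than the scatter. The expected change is a 1.5-fold higher number from compound 3 to compound 4 (0.18 log units; within the scatter) in this estimate. Compound 4 is estimated at 3500 nM with 1200 nM to 10000 nM as the expected range.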

Compound 4, half-maximal inhibitory concentration: > 20000 nM
Compound 4: only a limit was reported (the forecaster's own chance of this, stated with the estimate: 5%); middle value at least 5.7-fold (0.75 log units) away from the limit.
By their numbers in this assay, from the lowest: compound 3; then compound 1; then compound 2. At a limit, above all of these: compound 4.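

In this assay, compound 4 gives > 20000 nM, which is a limit of the assay and not a number. Within the data shown here, putting 2,4-dichlorophenyl in place of 3,5-dimethoxyphenyl on a double-bonded chain carbon bound to a double-bonded ring carbon gives an at least 8.6-fold higher number from compound 3 to compound 4 (0.93 log units; beyond the scatter), the first step in this set that changes one place only, and it lies beyond the usual scatter. This position therefore responds clearly to the group it carries, though the full size of that response cannot be read from a value sitting at the limit: the limit of > 20000 nM in this assay, at which 1 of the 4 values shown sits.

The step cannot separate the effect of gaining the two chlorines from that of losing the two methoxy groups. It also leaves open how this position would respond to a phenyl ring carrying an amine or a carboxylic acid.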